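A few compounds are considered here, and "the series" means these few. Any claim that something is new, unique, unknown or untested is made for them only; others in the source may bear on it.

Measured so far in an ADME assay on Vero cells (Chlorocebus sabaeus) for cytotoxicity, read by MTT assay, with a stated time of 72 h; a lower number here means a stronger inhibitor, a higher number a weaker inhibitor:

- compound 1, `Brc1ccccc1-c1nnc(-c2ccc(-n3cccc3)cc2)o1`: 258000 nM
- compound 2, `CC(=O)N1N=C(c2ccc(-n3c(C)ccc3C)cc2)OC1c1ccc(N(C)C)cc1`: 175000 nM
- compound 3, `O=C(NNC(=O)c1ccc(-n2cccc2)cc1)c1ccccc1`: 200000 nM

Compound 2 sits at the low end of the three numbers, but the gaps to compound 3 and to compound 1 both lie within the usual scatter, so in this assay the three compounds cannot be told apart. Among the measured compounds shown here, no step between two measured compounds that differ in a single place is available, so the series gives no read on how a single change moves the number.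

Compound 4, `CC(=O)N1N=C(c2ccc(-n3c(C)ccc3C)cc2)OC1c1cccc([N+](=O)[O-])c1`, has not yet been measured. It is built from compound 2 by one change:

3-nitrophenyl in place of 4-(dimethylamino)phenyl on a saturated ring carbon

For the measured compounds named here, with no measured single-place step to lean on, and with all three measured values clustered together, the expectation for the step from compound 2 to compound 4 is none beyond the scatter, in either direction; the estimated step is a 1.0-fold higher number from compound 2 to compound 4 (0.01 log units; within the scatter). Compound 4 is therefore expected to give about 180000 nM in this assay, with a range from 80000 nM to 400000 nM.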

Compound 4, half-maximal inhibitory concentration: 188000 nM
Estimate against measurement, compound 4: 1.0-fold (0.02 log units) below, and the stated range covers the measured number.
By their numbers in this assay, from the lowest: compounds 2, 4, 3 and 1 (each within the scatter of the next).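

In this assay, the series now has its first single-place step, a 1.1-fold higher number from compound 2 to compound 4 (0.03 log units; within the scatter), and it lies within the scatter. On this saturated ring carbon, 3-nitrophenyl and 4-(dimethylamino)phenyl therefore cannot be told apart, even though the exchange replaces a carbon and nitrogen group with one that also carries oxygen and a double bond outside the aromatic ring. Nothing at hand explains why the two groups read alike.

Still open, as far as these compounds go, is whether a carboxylic acid, a primary amine or a longer alkyl chain on this same ring carbon would give a step beyond the scatter. Also open, from the compounds shown here alone, is how the number responds to a change at the ring atom that bears the acetyl group, for example a propanoyl group in place of acetyl.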